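This account rests on a few compounds, and the source may have more. Where it says the series, first, only, none or still open, it means among the compounds named here.

Measured so far in an assay on isolated protein for inhibition of sphingosine-1-phosphate lyase 1 (Homo sapiens), using Lineweaver-Burk analysis; on this read-out higher numbers stand for weaker inhibition and lower numbers for stronger inhibition:
compound 1 `CCCCCCCCCCCCCCC[C@H](O)[C@H](COP(=O)(O)O)N=[N+]=[N-]` 16400 nM
compound 2 `CCCCCCCCCCCCCCC[C@H](O)[C@@H](COP(=O)(O)O)N=[N+]=[N-]` 6300 nM
compound 3 `CCCCCCCCCCCCC/C=C/[C@@H](O)[C@@H](COP(=O)(O)O)N=[N+]=[N-]` 17500 nM

Compound 3 gives the highest number of the three; against compound 1 the gap is within the scatter, against compound 2 it is beyond it. Compound 4 `CCCCCCCCCCCCC/C=C/[C@@H](O)[C@H](COP(=O)(O)O)N=[N+]=[N-]` differs from compound 3 only by the two compounds have the same atoms and bonds; at least one stereo element is drawn with a configuration in one of them and without one in the other: 1 of 4 stereo elements differ; a stereocentre at a saturated chain carbon is drawn R in compound 3 and S in compound 4. Among the compounds with values here, the one measured step that bears on this is the inversion at the same saturated chain carbon in the saturated pair, a 2.6-fold lower number from compound 1 to compound 2 (0.42 log units; beyond the scatter), where the configuration drawn in compound 2 matches that of compound 3. Running that step in reverse, a modest rise in this assay is expected for compound 4, a 2.3-fold higher number from compound 3 to compound 4 (0.36 log units; beyond the scatter). Compound 4 is therefore estimated at 40000 nM, between 15000 nM and 100000 nM.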

Compound 4, inhibition constant: 9100 nM
The estimate for compound 4 lay 4.4-fold (0.64 log units) above the measured number; the measured number lies below the stated range.
By their numbers in this assay, from the lowest: compounds 2, 4, 1 and 3 (each within the scatter of the next, the first and the last beyond it).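

In this assay, inverting the saturated chain carbon from R to S gives a 1.9-fold lower number from compound 3 to compound 4 (0.28 log units; within the scatter), so compound 3 and compound 4 are not separated at this position. The saturated pair had shown a separation, a 2.6-fold lower number from compound 1 to compound 2 (0.42 log units; beyond the scatter), with R giving the lower number, and that preference for R is not reproduced in the pair carrying the chain double bond.

From the compounds shown here alone, whether this inversion would separate compounds carrying an amine in place of the azide remains open. The same question stands for a longer chain.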